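Amide-to-acid swap on the aminonitrile series

This account rests on a few compounds, and the source may have more. Where it says the series, first, only, none or still open, it means among the compounds named here.

Measured compounds:
- Compound 1, `CC[C@@H](Nc1c(C#N)c(-c2ccc(-c3ccccc3CO)cc2)nc2cnccc12)C(N)=O`, in a physicochemical assay for lipophilicity, read by HPLC, at pH 7.5 (a lower number here means a more polar compound, a higher number a more lipophilic compound), gives 2.1.
- Compound 2, `CCOc1ccccc1-c1ccc(-c2nc3cnccc3c(N[C@H](CC(C)C)C(N)=O)c2C#N)cc1`, in this assay gives 3.4.
- Compound 3, `CC[C@@H](Nc1c(C#N)c(-c2ccc(-c3cccc(Cl)c3OC)cc2)nc2cnccc12)C(N)=O`, in this assay gives 3.1.

Going by the values given here, compound 2 stands highest of the three numbers so far; its nearest neighbour is compound 3, within the scatter, and compound 1 lies furthest from it, beyond the scatter. Among the compounds with values here, the only single-point step among the measured compounds is a number 1.00 log units higher from compound 1 to compound 3 (beyond the scatter), and it concerns the aryl substituent, not the amino side chain.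

The next compound, compound 4, `CCOc1ccccc1-c1ccc(-c2nc3cnccc3c(N[C@H](CC)C(=O)O)c2C#N)cc1`, differs from compound 2 at the amino side chain: 1-carboxypropyl in place of 1-carbamoyl-3-methylbutyl on a nitrogen on an aromatic ring. No measured step covers this kind of change, so the expectation rests on the nature of the swap alone rather than on any shown step. A step lower in this assay is expected, larger than the scatter. For compound 4 a value of 1.4 is estimated, with a range from 0.6 to 2.2, which corresponds to an expected step of a number 2.00 log units lower from compound 2 to compound 4 (beyond the scatter).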

Compound 4, distribution coefficient: 2.1
Beside the measured number, compound 4's estimate is 0.70 log units below it; measured number inside the range.
By their numbers in this assay, from the lowest: compounds 1 and 4 (each within the scatter of the next); then compounds 3 and 2 (each within the scatter of the next).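

Working notes: in this assay, the amino side chain is now also a position where the number responds, since the change from (1-carbamoyl-3-methylbutyl)amino to (1-carboxypropyl)amino gives a number 1.30 log units lower from compound 2 to compound 4 (beyond the scatter), whereas the only earlier step, a number 1.00 log units higher from compound 1 to compound 3 (beyond the scatter), lay in the aryl substituent. This single step carries two changes at once, carbamoyl to carboxy and a change in the chain, so its size belongs to the pair and cannot be divided between them. No supporting data are available to explain the step.

As far as these compounds go, the split remains open: 1-carboxy-3-methylbutyl on the same nitrogen, with the rest of compound 2 kept, would isolate the carbamoyl-to-carboxy change. From the compounds shown here alone, how an amine or a longer chain ending in a carboxylic acid would read at this place also remains open.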